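Disulfide-linked nucleoside chain length and half-life

A few compounds are considered here, and "the series" means these few. Any claim that something is new, unique, unknown or untested is made for them only; others in the source may bear on it.

Compound 3 `Cc1cn([C@H]2C[C@H](SSCCO)[C@@H](CO)O2)c(=O)[nH]c1=O` stands at the lower end of everything measured here: in a physicochemical assay for pharmacokinetics, at pH 7.2 (on this read-out higher numbers stand for a longer-lived compound and lower numbers for a shorter-lived compound), compound 3 gives < 0.0834 h, which is a limit of the assay rather than a number. Compound 1 `CCCCCCSS[C@H]1C[C@H](n2cc(C)c(=O)[nH]c2=O)O[C@@H]1CO` gives < 0.0834 h, also a limit. Compound 2 `CCCCCCCCSS[C@H]1C[C@H](n2cc(C)c(=O)[nH]c2=O)O[C@@H]1CO` gives < 0.0834 h, again a limit. Thus (the limit of < 0.0834 h in this assay, at which 3 of the 3 values shown sit). The steps a step that the two limits leave unreadable from compound 1 to compound 2, a step that the two limits leave unreadable from compound 1 to compound 3 and a step that the two limits leave unreadable from compound 2 to compound 3 are all unreadable. Compound 4 `Cc1cn([C@H]2C[C@H](SSCCCCCCO)[C@@H](CO)O2)c(=O)[nH]c1=O` differs from compound 3 by 4-hydroxybutyl in place of hydroxy on a saturated chain carbon, two bonds along the chain from a sulfur. Among the measured compounds shown here, no measured step gives a readable size, so compound 4 is expected to sit where all three sit, with a step that the limit leaves unreadable from compound 3 to compound 4 expected to be unreadable. The estimate for compound 4 is 0.05 h, ranging from 0.01 h to 0.2 h.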

Compound 4, half-life: < 0.0834 h
Compound 4: no number, only a limit; the forecaster's own chance of this, stated with the estimate: 85%; the middle value does not contradict the limit.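

Compound 4 sits at the same limit as compound 1, compound 2 and compound 3, so none of its steps to them can be read: the limit of < 0.0834 h in this assay, at which 4 of the 4 values shown sit.

The compounds shown leave open how long any of them actually lasts in this assay, and whether chain length or the terminal hydroxy makes any difference there.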